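Secondary amine restored and methoxy added on benzyl group

The compounds below may be only part of what the source reports. "The series", "measured", "known", "first", "only" and "open" are said of these compounds alone.

Measured compounds:
Compound 1 `O=S(=O)(NCCCNCc1ccccc1Cl)c1cc(C(F)(F)F)cc(C(F)(F)F)c1` gives 15000 nM in a functional assay on PANC-1 cells (Homo sapiens) for inhibition, read by MTT assay, with a stated time of 72 h; on this read-out lower numbers stand for stronger inhibition of growth and higher numbers for weaker inhibition of growth.
Compound 2 `CC(C)(C)c1ccc(CNCCCNS(=O)(=O)c2cc(C(F)(F)F)cc(C(F)(F)F)c2)cc1` gives 2500 nM in this assay.
Compound 3 `CN(CCCNS(=O)(=O)c1cc(C(F)(F)F)cc(C(F)(F)F)c1)Cc1ccccc1` gives > 50000 nM in this assay; this is a limit of the assay, not a number.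

Compound 3 therefore stands at the weak end of the measured set, and only its limit is known, as stated by the limit of > 50000 nM in this assay, at which 1 of the 3 values shown sits. Compound 4 `COc1ccc(CNCCCNS(=O)(=O)c2cc(C(F)(F)F)cc(C(F)(F)F)c2)cc1` differs from it by (4-methoxybenzyl)amino in place of benzyl(methyl)amino on a saturated chain carbon, three bonds along the chain from a sulfonamide nitrogen. Two measured steps speak to this change. The step of an at least 3.3-fold higher number from compound 1 to compound 3 (0.52 log units; beyond the scatter) shows that adding a methyl on the amine nitrogen weakens growth inhibition, so returning to an amine carrying a hydrogen, as in compound 4, should undo that loss. The step of a 6.0-fold lower number from compound 1 to compound 2 (0.78 log units; beyond the scatter) shows that a 4-substituted benzyl group gives a stronger result than a 2-chlorobenzyl group, and compound 4 also carries a substituent in the 4-position of the benzyl ring. On this basis a clear drop in the number in this assay is expected, roughly as large as the sum of the two effects. Compound 4 is expected to give 8000 nM, within 2500 nM to 30000 nM, corresponding to the expected step of an at least 6.2-fold lower number from compound 3 to compound 4 (0.79 log units; beyond the scatter).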

Compound 4, concentration for 50% growth inhibition: 11000 nM
Beside the measured number, compound 4's estimate is 1.4-fold (0.14 log units) below it; measured number inside the range.
By their numbers in this assay, from the lowest: compound 2; then compounds 4 and 1 (each within the scatter of the next). At a limit, above all of these: compound 3.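

In this assay, the change from compound 3 gives an at least 4.5-fold lower number from compound 3 to compound 4 (0.65 log units; beyond the scatter) and so brings measurable growth inhibition, but the size of this step is only a minimum, since compound 3 has a limit and not a number: the limit of > 50000 nM in this assay, at which 1 of the 4 values shown sits. Among the compounds whose amine carries a hydrogen, the new result gives a 1.4-fold lower number from compound 1 to compound 4 (0.13 log units; within the scatter) and this lies within the scatter, so 4-methoxyphenyl and 2-chlorophenyl cannot be told apart on this chain carbon. The group on the aromatic carbon does matter, as methoxy in place of tert-butyl gives a 4.4-fold higher number from compound 2 to compound 4 (0.64 log units; beyond the scatter) and shows that the stronger result of compound 2 goes with 4-(tert-butyl)phenyl and is not shared by every 4-substituted benzyl group shown.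

The step from compound 3 changes both the amine and the ring, so the compounds shown cannot say how much of it belongs to the amine hydrogen and how much to the methoxy, a question that a plain benzyl group on an amine carrying a hydrogen would address. Going by these compounds, it also stays open whether a 4-isopropylphenyl or 4-cyclohexylphenyl group would read like 4-(tert-butyl)phenyl in this assay on this chain carbon.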